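Chloromethylbenzyl Purines: Cytotoxicity Notes, Compound 2 to 3

The source may hold more compounds than are shown below. What is called first, only, known or untested is meant among the compounds shown, and "the series" means these compounds.

Measured so far:
- compound 1, `ClCc1ccccc1Cn1cnc2c(Cl)nc(Cl)nc21`: > 100000 nM
- compound 2, `ClCc1cccc(Cn2cnc3c(Cl)ncnc32)c1`: > 100000 nM

Both values in a functional assay on HT-29 cells (Homo sapiens) for cytotoxicity, read by sulforhodamine B assay, with a stated time of 48 h (a higher number here means that more compound is tolerated, a lower number that less compound is tolerated), are limits of the assay rather than numbers. For compound 2 the value > 100000 nM is such a limit. The same holds for compound 1, whose value > 100000 nM is also a limit. Compound 2 therefore stands at the limit of > 100000 nM in this assay, at which 2 of the 2 values shown sit, and nothing in the shown numbers separates it from compound 1.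

Compound 3, `Nc1nc(Cl)c2ncn(Cc3cccc(CCl)c3)c2n1`, is the next compound to be measured in this assay. It differs from compound 2 by amino in place of hydrogen on an aromatic carbon; the place is an aromatic carbon of a six-membered aromatic ring with two nitrogen atoms, part of a fused system of two rings, between two ring nitrogen atoms, meta to a chloro group, meta to a fused ring and para to a fused ring.

No step between measured compounds is available to calibrate this change, and both shown values sit at the limit. The expected step from compound 2 to compound 3 in this assay is a number no higher from compound 2 to compound 3 (the limit leaves the size open), that is, none beyond the scatter. For compound 3 the expected value in this assay is 100000 nM, with a range of 30000 nM to 300000 nM, and most likely only a limit will again be reported.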

Compound 3, concentration lethal to 50% of the cells: 64600 nM
The estimate for compound 3 lay 1.5-fold (0.19 log units) above the measured number, within the range that was stated.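

In this assay, compound 3, with amino on the aromatic carbon between two ring nitrogen atoms, is the one compound shown that gives a number rather than a limit: the limit of > 100000 nM in this assay, at which 2 of the 3 values shown sit.

Compound 2 gives > 100000 nM, which is a limit. From the compounds shown here alone, the change from hydrogen to amino at this position therefore reads only as an at least 1.5-fold lower number from compound 2 to compound 3 (0.18 log units; that floor lies within the scatter), so this position tolerates amino with a measurable read-out, while the true size of the step stays unknown.

Going by these compounds, it remains open whether a methylamino or a hydroxyl group on the same aromatic carbon would also give a number in this assay. Also open, on these data alone, is whether amino at this position would give a step of similar size on the core of compound 1.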